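Cytotoxicity series: from compound 2 toward compound 3

The source may hold more compounds than are shown below. What is called first, only, known or untested is meant among the compounds shown, and "the series" means these compounds.

Compound 1, `CN(C)c1ccc(/C=N/Nc2nc3ccccc3s2)cc1`, in a functional assay on HCT-8 cells (Homo sapiens) for cytotoxicity, read by MTT assay, with a stated time of 72 h (on this read-out lower numbers stand for stronger inhibition and higher numbers for weaker inhibition), gives > 16800 nM.
Compound 2, `Brc1ccc(/C=N/Nc2nc3ccccc3s2)cc1`, in this assay gives > 15000 nM.

The value of compound 1 is only a limit of this assay, not a number. The value of compound 2 is likewise only a limit. Going by the values given here, the one measured step, a step that the two limits leave unreadable from compound 1 to compound 2, is therefore not readable in size or direction; the two values sit at the limit of > 15000 nM in this assay, at which 1 of the 2 values shown sits, and (the limit of > 16800 nM in this assay, at which 1 of the 2 values shown sits).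

Compound 3, `C(=N/Nc1nc2ccccc2s1)\c1ccc(-c2ccccn2)cc1`, has not yet been measured. It differs from compound 2 by pyridin-2-yl in place of bromo on an aromatic carbon. Among the compounds with values here, no measured step gives a readable size for a change of this kind, and no reference number exists for compound 2 beyond its limit. With both measured compounds at limits, compound 3 is expected to stay near the same level. The step expected in this assay is a step that the limit leaves unreadable from compound 2 to compound 3. For compound 3 the estimate is 20000 nM, within 4000 nM to 100000 nM, with a fair chance that this assay again returns only a limit.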

Compound 3, half-maximal inhibitory concentration: > 15100 nM
Compound 3 was reported as a limit (the forecaster's own chance of this, stated with the estimate: 65%); the middle value does not contradict the limit.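

In this assay compound 3 gives > 15100 nM, again only a limit, so neither the step from compound 1 to compound 3 nor that from compound 2 to compound 3 can be read. The compounds shown leave open whether any group at this aromatic carbon gives a number rather than a limit.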